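The compounds below may be only part of what the source reports. "The series", "measured", "known", "first", "only" and "open" are said of these compounds alone.

Measured compounds:
Compound 1 `CCn1c(C(=O)NCC#N)ccc1C(CC)(CC)c1ccc(OCCC(O)(CC)CC)c(C)c1` gives 1080 nM in an assay on cells for agonist activity at vitamin D3 receptor (Homo sapiens), with a stated time of 96 h; on this read-out lower numbers stand for an effect already at smaller amounts and higher numbers for an effect only at larger amounts of compound.
Compound 2 `C=CCN(C)C(=O)c1ccc(C(CC)(CC)c2ccc(OCCC(O)(CC)CC)c(C)c2)n1CC` gives > 10000 nM in this assay, which is a limit of the assay and not a number.

Compound 2 therefore stands only at the limit of this assay, as shown by the limit of > 10000 nM in this assay, at which 1 of the 2 values shown sits, and the step of an at least 9.2-fold higher number from compound 1 to compound 2 (0.96 log units; beyond the scatter) records only how far compound 2 falls short of compound 1 when allyl(methyl)amino replaces (cyanomethyl)amino on the carbonyl carbon. Compound 3 `C#CC(C)OC(=O)c1ccc(C(CC)(CC)c2ccc(OCCC(O)(CC)CC)c(C)c2)n1CC` has not yet been measured. It differs from compound 2 by (1-methylprop-2-yn-1-yl)oxy in place of allyl(methyl)amino on a carbonyl carbon, so the amide nitrogen of compound 2 is replaced by an ester oxygen while the carbonyl and the rest of the shared core stay the same. Among the compounds with values here, only the single step from compound 1 to compound 2 bears on this change, and it concerns the amine side rather than an exchange of nitrogen for oxygen, so its guidance is indirect. Since compound 2 sits at the limit, the step is expected to be an at least 1.4-fold lower number from compound 2 to compound 3 (0.15 log units; that floor lies within the scatter), with a real chance of another limit. Compound 3 is estimated at 7000 nM in this assay, within a range from 1500 nM to 30000 nM.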

Compound 3, half-maximal effective concentration: 2650 nM
Compound 3: middle estimate off by 2.6-fold (0.42 log units), on the high side; the range from low to high includes it.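

On this carbonyl carbon in this assay, the loss seen with allyl(methyl)amino does not extend to every larger group: (1-methylprop-2-yn-1-yl)oxy in its place gives an at least 3.7-fold lower number from compound 2 to compound 3 (0.57 log units; beyond the scatter), so a group joined through oxygen returns a measurable number. As far as these compounds go, compound 2 stands at a limit of the assay and not at a number, so this step is only a floor and its true size remains unknown: the limit of > 10000 nM in this assay, at which 1 of the 3 values shown sits. Measured against (cyanomethyl)amino, the same oxygen-linked group gives a 2.5-fold higher number from compound 1 to compound 3 (0.39 log units; beyond the scatter), so the (cyanomethyl)amino amide keeps the lowest number of the three, while the allyl(methyl)amino amide goes against any rule that amides as a class outdo the ester here.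

The compounds shown leave open whether the recovery belongs to the ester oxygen or to the alkyne-bearing chain, since both differ at once between the two groups; allyloxy or (1-methylprop-2-yn-1-yl)amino on the same carbonyl carbon would separate them. Also open, from the compounds shown here alone, is how a free carboxylic acid or a simple methyl ester would read at this position.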